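This account rests on a few compounds, and the source may have more. Where it says the series, first, only, none or still open, it means among the compounds named here.

Compound 1 `c1ccc(CO/N=C2/C(c3c[nH]c4ccccc34)=Nc3ccccc32)cc1`: in a functional assay on SK-OV-3 cells (Homo sapiens) for cytotoxicity, read by MTT assay, with a stated time of 2 days (on this read-out lower numbers stand for stronger inhibition and higher numbers for weaker inhibition), compound 1 gives 16900 nM
Compound 2 `Fc1ccc2c(c1)/C(=N\OCc1ccccc1)C(c1c[nH]c3ccc(F)cc13)=N2`: compound 2 gives 12300 nM
Compound 3 `Cc1ccc(CO/N=C2/C(c3c[nH]c4ccccc34)=Nc3ccccc32)cc1`: compound 3 gives 32400 nM

Compound 2 gives the lowest of the three numbers in this assay. Its nearest neighbour is compound 1, and the two lie within the scatter of each other, so no order between them can be claimed; compound 3 stands beyond the scatter from compound 2. Compound 4 `Cc1ccc(CO/N=C2/C(c3c[nH]c4ccc(F)cc34)=Nc3ccc(F)cc32)cc1` has not yet been measured. It differs from compound 2 by methyl in place of hydrogen on an aromatic carbon. For the measured compounds named here, one measured step bears on this change: a 1.9-fold higher number from compound 1 to compound 3 (0.28 log units; within the scatter), the same replacement on the benzyl group of the shared core, though in compounds lacking the fluorine substituents carried by compound 2 and compound 4. On that basis a small move toward a higher number is expected for compound 4, likely staying within the scatter, and the step expected is a 1.6-fold higher number from compound 2 to compound 4 (0.21 log units; within the scatter). Compound 4 is therefore estimated at 20000 nM, with a range from 9000 nM to 45000 nM.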

Compound 4, half-maximal inhibitory concentration: 11300 nM
The estimate for compound 4 lay 1.8-fold (0.25 log units) above the measured number; the range from low to high includes it.
By their numbers in this assay, from the lowest: compounds 4, 2, 1 and 3 (each within the scatter of the next, the first and the last beyond it).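

In this assay, the replacement of hydrogen by methyl on the benzyl group now has a second reading, on the core carrying the fluorine substituents: a 1.1-fold lower number from compound 2 to compound 4 (0.04 log units; within the scatter). Neither this step nor the earlier one on the core of compound 1 leaves the scatter, so methyl at this place, para to a large group, shows no change that can be claimed on either core. The two readings also agree with each other: the same change on two cores in this assay, a 1.9-fold higher number (0.28 log units; within the scatter) from compound 1 to compound 3 and a 1.1-fold lower number (0.04 log units; within the scatter) from compound 2 to compound 4, 2.1-fold (0.32 log units) apart, within the scatter of two such steps.

On these data alone, what a larger group at this place would do, such as a methoxy, an amine or a carboxylic acid, remains open. As far as these compounds go, compound 1 and compound 2 differ in more than one place, so the separate contribution of each fluorine also remains open.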